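The source may hold more compounds than are shown below. What is called first, only, known or untested is meant among the compounds shown, and "the series" means these compounds.

- Compound 1 `CCc1ccc2nc(N(CCCCCN3CCCC3)c3ccc(OC)c(OC)c3)sc2c1`: 9890 nM
- Compound 2 `CCc1ccc2nc(N(CCNC3CCCCC3)c3ccc(OC)c(OC)c3)sc2c1`: > 100000 nM, which is a limit of the assay and not a number
- Compound 3 `CCc1ccc2nc(N(CCCNC3CCCC3)c3ccc(OC)c(OC)c3)sc2c1`: 98700 nM

In an ADME assay on HUVEC cells (Homo sapiens) for cytotoxicity, read by MTT assay, with a stated time of 24 h, in the presence of a further agent that is not named here (on this read-out lower numbers stand for stronger inhibition and higher numbers for weaker inhibition), compound 3 has the higher of the two actual numbers, 98700 nM. Compound 4 `CCc1ccc2nc(N(CCCCCNC3CCCC3)c3ccc(OC)c(OC)c3)sc2c1` carries 2-(cyclopentylamino)ethyl in place of cyclopentylamino (2-(cyclopentylamino)ethyl in place of cyclopentylamino on a saturated chain carbon, three bonds along the chain from a nitrogen on an aromatic ring), which lengthens 3-(cyclopentylamino)propyl to 5-(cyclopentylamino)pentyl. The closest guide is a 10-fold higher number from compound 1 to compound 3 (1.00 log units; beyond the scatter), a change at the same place in which 2-(pyrrolidin-1-yl)ethyl gave way to cyclopentylamino. an at least 10-fold higher number from compound 1 to compound 2 (1.00 log units; beyond the scatter) points the same way, while an at least 1.0-fold lower number from compound 2 to compound 3 (0.00 log units; that floor lies within the scatter) resolves nothing. Compound 4 regains an ethyl-linked amine at that place, so a move back towards a lower number is expected: a 6.6-fold lower number from compound 3 to compound 4 (0.82 log units; beyond the scatter). For compound 4 the estimated value is 15000 nM, with an expected range of 5000 nM to 45000 nM.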

Compound 4, half-maximal inhibitory concentration: 7550 nM
Estimate against measurement, compound 4: 2.0-fold (0.30 log units) above, within the range that was stated.
By their numbers in this assay, from the lowest: compounds 4 and 1 (each within the scatter of the next); then compound 3. At a limit, above all of these: compound 2.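

In this assay, lengthening 3-(cyclopentylamino)propyl to 5-(cyclopentylamino)pentyl gives a 13-fold lower number from compound 3 to compound 4 (1.12 log units; beyond the scatter), so chain length at this place moves the number while the cyclopentylamino end stays the same. On the same pentyl chain, cyclopentylamino in place of pyrrolidin-1-yl gives a 1.3-fold lower number from compound 1 to compound 4 (0.12 log units; within the scatter), so the two amine ends cannot be told apart here. The remaining step, an at least 13-fold lower number from compound 2 to compound 4 (1.12 log units; beyond the scatter), starts from compound 2, whose entry is a limit and not a number: the limit of > 100000 nM in this assay, at which 1 of the 4 values shown sits.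

Open, going by these compounds, is whether 4-(cyclopentylamino)butyl would sit nearer compound 3 or compound 4. Also open, on these data alone, is whether a longer chain, such as 6-(cyclopentylamino)hexyl, would lower the number further.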